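A few compounds are considered here, and "the series" means these few. Any claim that something is new, unique, unknown or untested is made for them only; others in the source may bear on it.

In a toxicity assay on THP-1 cells (Homo sapiens) for inhibition (on this read-out higher numbers stand for lower toxicity in this test and lower numbers for higher toxicity in this test), compound 3 `COc1ccc(-c2cnc(NC(=O)c3ccc(F)cc3)n2C)cc1` gives >= 50000 nM, which is a limit and not a number. Compound 1 `Cn1c(-c2ccccc2F)cnc1NC(=O)c1ccc(F)cc1` gives > 100000 nM, also a limit. Compound 2 `Cn1c(-c2ccc(Br)cc2)cnc1NC(=O)c1ccc(F)cc1` gives 46000 nM. Compound 4 `COc1ccccc1-c1cnc(NC(=O)c2ccc(F)cc2)n1C` has 2-methoxyphenyl in place of 4-methoxyphenyl on an aromatic carbon. The nearest evidence is the change that swaps 2-fluorophenyl for 4-bromophenyl, an at least 2.1-fold lower number from compound 1 to compound 2 (0.33 log units; beyond the scatter), which is modest. The swap of bromo for methoxy gives an at least 1.0-fold higher number from compound 2 to compound 3 (0.03 log units; that floor lies within the scatter), and a step that the two limits leave unreadable from compound 1 to compound 3 cannot be sized. Among the compounds with values here, compound 1 is the only measured compound with a 2-substituted phenyl, so this is thin support for a small rise at most. The expected change is a step that the limit leaves unreadable from compound 3 to compound 4, toward lower toxicity. Compound 4 is expected near 80000 nM, with an estimated range of 40000 nM to 160000 nM.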

Compound 4, half-maximal cytotoxic concentration: > 100000 nM
Compound 4 ended at the assay's limit (the forecaster's own chance of this, stated with the estimate: 65%); middle value at least 1.2-fold (0.09 log units) away from the limit.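

With 2-methoxyphenyl on the shared core, the number rises clearly over the 4-bromophenyl of compound 2, an at least 2.1-fold higher number from compound 2 to compound 4 (0.33 log units; beyond the scatter). This gives a second 2-substituted phenyl, after compound 1, that lies beyond the scatter from compound 2. The steps to compound 4 from compound 3 and from compound 1 cannot be read, as each joins two limits.

From the compounds shown here alone, whether moving the methoxy changes toxicity at all therefore stays open. Also open, going by these compounds, is whether an amine or a carboxylic acid on that phenyl ring would reach the same limit.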